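Solubility notes: thiazolyl addition to the tert-butyl analogue

The source may hold more compounds than are shown below. What is called first, only, known or untested is meant among the compounds shown, and "the series" means these compounds.

Measured so far in a physicochemical assay for solubility, in phosphate buffer, with a stated time of 18 h; a higher number here means a more soluble compound, a lower number a less soluble compound:
compound 1, `N#Cc1c(N)nc2nc(C3CCCCC3)ncc2c1N` — 81000 nM
compound 2, `CC(C)(C)c1ncc2c(N)c(C#N)c(N)nc2n1` — 37200 nM

Compound 2 stands lowest of the two numbers; its nearest neighbour is compound 1, which gives the higher number. Going by the values given here, the one measured step, a 2.2-fold lower number from compound 1 to compound 2 (0.34 log units; beyond the scatter), covers the exchange of tert-butyl for cyclohexyl on an aromatic carbon and is the only scale of variation available in this assay so far.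

Compound 3, `CC(C)(C)c1nc(-c2nccs2)c2c(N)c(C#N)c(N)nc2n1`, carries the change (1,3-thiazol-2-yl in place of hydrogen on an aromatic carbon). Among the compounds with values here, no measured step follows this change, so the step from compound 1 to compound 2 does not bear on it directly; it only shows that a single substituent change has moved the number beyond the scatter. Adding a whole aromatic ring where a hydrogen stood is a larger change than that, and a lower number is expected for compound 3, with the step of a 3.7-fold lower number from compound 2 to compound 3 (0.57 log units; beyond the scatter) expected to exceed the scatter. The estimate for compound 3 in this assay is 10000 nM, with a range from 2500 nM to 40000 nM.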

Compound 3, solubility: < 1500 nM
Compound 3 gave a limit, no number (the forecaster's own chance of this, stated with the estimate: 10%); middle value at least 6.6-fold (0.82 log units) away from the limit.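

In this assay the placing of 1,3-thiazol-2-yl in place of hydrogen on the aromatic carbon next to the ring nitrogen gives an at least 24-fold lower number from compound 2 to compound 3 (1.39 log units; beyond the scatter) and so shows that this carbon, which holds hydrogen in compound 1 and compound 2 alike, is a place where the number can move strongly. Going by these compounds alone, the only earlier step is a 2.2-fold lower number from compound 1 to compound 2 (0.34 log units; beyond the scatter) and concerns the exchange of cyclohexyl for tert-butyl, and it is much the smaller of the two. Compound 3 stands at a limit of the assay and not at a number, so the full size of its step stays unknown: the limit of < 1500 nM in this assay, at which 1 of the 3 values shown sits.

The compounds shown leave open whether this fall belongs to the thiazolyl ring itself or to any group at this carbon, and a methyl group, an amine or a carboxylic acid at the same place would separate the two readings. They also leave open how far compound 3 lies beyond its limit, and whether the same addition to compound 1, with cyclohexyl in place of tert-butyl, gives a step of like size.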